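The compounds below may be only part of what the source reports. "The series", "measured", "known", "first", "only" and "open" are said of these compounds alone.

Compound 1 has the structure `O=C(/C=C\Nc1ccc(F)cc1)c1nc(-c2ccc(F)cc2)n2ccccc12`. In a functional assay on B16-F10 cells (Mus musculus) for cytotoxicity, read by MTT assay, with a stated time of 48 h (a lower number here means a stronger inhibitor, a higher number a weaker inhibitor), compound 1 gives > 30000 nM, which is a limit of the assay and not a number.
Compound 2 has the structure `COc1ccc(N/C=C\C(=O)c2nc(-c3ccc(C(F)(F)F)cc3)n3ccccc23)cc1OC`. In this assay compound 2 gives > 30000 nM, again a limit.
Compound 3 has the structure `O=C(/C=C\Nc1ccc(Cl)cc1)c1nc(-c2ccc(C(F)(F)F)cc2)n2ccccc12`. In this assay compound 3 gives > 30000 nM, once more a limit.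

Compound 3 therefore stands at a limit of this assay, and no number for it is known. Among the measured compounds shown here, the only step between measured compounds that differ in one place, a step that the two limits leave unreadable from compound 2 to compound 3, cannot be read either, since both of its ends are limits.

Compound 4, with the structure `O=C(/C=C\Nc1ccc(Cl)cc1)c1nc(-c2ccc(F)cc2)n2ccccc12`, differs from compound 3 in one place: fluoro in place of trifluoromethyl on an aromatic carbon. For the measured compounds named here, no measured step bears directly on this change. What is known is the limit of > 30000 nM in this assay, at which 3 of the 3 values shown sit, and the change from trifluoromethyl to fluoro on the aromatic carbon is small in what is counted. Because (the limit of > 30000 nM in this assay, at which 3 of the 3 values shown sit), compound 4 is expected to give only a limit as well, with no step beyond the scatter in this assay. The estimate for compound 4 is 50000 nM, between 20000 nM and 200000 nM. This estimate means a step that the limit leaves unreadable from compound 3 to compound 4 that is expected to be unreadable.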

Compound 4, half-maximal inhibitory concentration: 11000 nM
Estimate against measurement, compound 4: 4.5-fold (0.66 log units) above, outside the stated range (below it).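

Compound 4 is the only compound shown that gives a number rather than a limit in this assay: the limit of > 30000 nM in this assay, at which 3 of the 4 values shown sit. Fluoro in place of trifluoromethyl on the aromatic carbon, para to a large group, gives an at least 2.7-fold lower number from compound 3 to compound 4 (0.43 log units; beyond the scatter), so this position, which looked silent while every value was a limit, can affect the read-out. Chloro in place of fluoro at the other changed place gives an at least 2.7-fold lower number from compound 1 to compound 4 (0.43 log units; beyond the scatter), and since compound 1 and compound 3 each carry only one of the two groups found in compound 4, only the pairing of chloro with fluoro gives a readable value among these compounds.

On these data alone, both steps start from a limit, so their full size remains unknown, and it is unclear how much each change would contribute with a different group at the other place. As far as these compounds go, it also remains open whether a bromo group, a methoxy group, an amine or a carboxylic acid on either aromatic carbon would lower the number further or return it to a limit.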